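Chloro in Place of Trifluoromethyl: What to Expect

The compounds below may be only part of what the source reports. "The series", "measured", "known", "first", "only" and "open" are said of these compounds alone.

Compound 1, `COc1cc2cc(Oc3ccc(NC(=O)Nc4cccc(C(F)(F)F)c4)cc3)c(C)nc2cc1OC`, gives 2060 nM in a functional assay on SN12C cells (Homo sapiens) for inhibition, read by sulforhodamine B assay, with a stated time of 48 h; a lower number here means a stronger inhibitor of growth, a higher number a weaker inhibitor of growth.
Compound 2, `COc1cc2cc(Oc3ccc(NC(=O)Nc4ccc(Cl)c(C(F)(F)F)c4)cc3)c(C)nc2cc1OC`, gives 1310 nM in this assay.

Going by the values given here, compound 2 has the lower of the two numbers, but the only measured step, a 1.6-fold lower number from compound 1 to compound 2 (0.20 log units; within the scatter), lies within the scatter, so the two compounds cannot be ranked. Compound 3, `COc1cc2cc(Oc3ccc(NC(=O)Nc4ccc(Cl)c(Cl)c4)cc3)c(C)nc2cc1OC`, differs from compound 2 by chloro in place of trifluoromethyl on an aromatic carbon. Among the compounds with values here, no measured step covers this change; the one step available concerns a different position and was itself within the scatter. Compound 3 is therefore expected to show no step beyond the scatter, a 1.1-fold higher number from compound 2 to compound 3 (0.06 log units; within the scatter). Compound 3 is estimated at 1500 nM, between 600 nM and 4000 nM.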

Compound 3, concentration for 50% growth inhibition: 3390 nM
Compound 3: middle estimate off by 2.3-fold (0.35 log units), on the low side; the range from low to high includes it.
By their numbers in this assay, from the lowest: compounds 2, 1 and 3 (each within the scatter of the next, the first and the last beyond it).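

Going by these compounds alone, putting chloro in place of trifluoromethyl, at the position ortho to a chloro group, gives a 2.6-fold higher number from compound 2 to compound 3 (0.41 log units; beyond the scatter) in this assay, the first step beyond the scatter, so these two groups are not interchangeable here. By contrast, 3,4-dichlorophenyl in place of 3-(trifluoromethyl)phenyl gives a 1.6-fold higher number from compound 1 to compound 3 (0.22 log units; within the scatter) and so allows no ranking. No available measurement explains why the two groups differ.

Going by these compounds, how a nitrile or an amine would fare at this position remains open. So does whether trifluoromethyl would keep its lead over chloro without the chloro group ortho to it.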